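From trifluoromethyl to methoxy in compound 4

The source may hold more compounds than are shown below. What is called first, only, known or untested is meant among the compounds shown, and "the series" means these compounds.

Of the compounds shown here, three with a shared core have been measured in a functional assay on MCF7 cells (Homo sapiens) for cytotoxicity, read by MTT assay, with a stated time of 24 h; a higher number here means a weaker inhibitor, a lower number a stronger inhibitor. Compound 1 (`CCNc1cc(-c2ccc(NC(=O)Nc3cccc4ccccc34)cc2C(F)(F)F)ccn1`) gives 16300 nM. Compound 2 (`CCNc1cc(-c2ccc(NC(=O)Nc3c(C)cccc3C)cc2C(F)(F)F)ccn1`) gives 6950 nM. Compound 3 (`CCNc1cc(-c2ccc(NC(=O)Nc3ccccc3Cl)cc2C(F)(F)F)ccn1`) gives 3680 nM. Compound 2 sits close to one neighbour and further from the other, with steps of a 1.9-fold lower number from compound 2 to compound 3 (0.28 log units; within the scatter) and a 2.3-fold lower number from compound 1 to compound 2 (0.37 log units; beyond the scatter).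

Compound 4 (`CCNc1cc(-c2ccc(NC(=O)Nc3c(C)cccc3C)cc2OC)ccn1`) departs from compound 2 in one place: methoxy in place of trifluoromethyl on an aromatic carbon. This puts methoxy in place of trifluoromethyl on an aromatic carbon, ortho to a 2-(ethylamino)pyridin-4-yl group.

Among the compounds with values here, no measured step touches this position. All three change the group on the amide-type nitrogen, and the widest, a 4.4-fold lower number from compound 1 to compound 3 (0.65 log units; beyond the scatter), is still modest. They show only the span of the set in this assay and give no direction for the new change, so no step beyond the scatter is expected. The estimated step is a 1.2-fold higher number from compound 2 to compound 4 (0.06 log units; within the scatter). For compound 4 the expected value is 8000 nM, with an estimated range from 3000 nM to 22000 nM.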

Compound 4, half-maximal inhibitory concentration: 9260 nM
Estimate against measurement, compound 4: 1.2-fold (0.06 log units) below; low and high end bracket the measured number.
By their numbers in this assay, from the lowest: compounds 3, 2, 4 and 1 (each within the scatter of the next, the first and the last beyond it).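

Within the data shown here, this pair gives the first reading at the position ortho to the 2-(ethylamino)pyridin-4-yl group: in this assay, methoxy in place of trifluoromethyl gives a 1.3-fold higher number from compound 2 to compound 4 (0.12 log units; within the scatter) and so does not separate from the scatter. With 2,6-dimethylphenyl on the amide-type nitrogen, trifluoromethyl is therefore not required to keep the number in this range, and the hydrogen-bond acceptor that methoxy brings makes no readable difference here. Nothing available explains why the two groups read alike.

As far as these compounds go, whether the exchange behaves the same way with 2-chlorophenyl or naphthalen-1-yl on the amide-type nitrogen remains open, as this is a single pair. Also open, from the compounds shown here alone, is how a nitrile, an amine or a longer ether chain such as ethoxy would read at this position in this assay.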